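The source may report more compounds than this note shows. Statements on the series, on what has been measured and on what is new or still open speak of the compounds shown alone.

Of the compounds shown here, two have been measured in a functional assay on HCT-116 cells (Homo sapiens) for cytotoxicity, read by MTT assay, with a stated time of 72 h; a higher number here means a weaker inhibitor, a lower number a stronger inhibitor. Compound 1 `CN1[C@@H]2c3[nH]c4ccccc4c3C[C@H]1[C@H](C#N)N1[C@@H](CNC(=O)c3ccc(F)cc3)c3[nH]c4ccccc4c3C[C@@H]21` gives 140 nM, and compound 2 `CN1[C@@H]2c3[nH]c4ccccc4c3C[C@H]1[C@H](C#N)N1[C@@H](CNC(=O)c3cccc4c3CCCC4)c3[nH]c4ccccc4c3C[C@@H]21` gives 4210 nM, the higher of the two numbers. For the measured compounds named here, the single step between them, a 30-fold higher number from compound 1 to compound 2 (1.48 log units; beyond the scatter), is the only measured change that bears on the next compound. Compound 3 `CN1[C@@H]2c3[nH]c4ccccc4c3C[C@H]1[C@H](C#N)N1[C@@H](CNC(=O)c3ccc4ccccc4c3)c3[nH]c4ccccc4c3C[C@@H]21` differs from compound 2 by naphthalen-2-yl in place of 1,2,3,4-tetrahydronaphthalen-5-yl on a carbonyl carbon. Going by the values given here, the one relevant step shows that a second ring joined to the aryl group on the carbonyl carbon went together with a large loss in this assay; compound 3 keeps a second ring but attaches it as naphthalen-2-yl rather than 1,2,3,4-tetrahydronaphthalen-5-yl, so the data cannot say whether that loss carries over. Compound 3 is therefore expected to give a step of a 3.5-fold lower number from compound 2 to compound 3 (0.55 log units; beyond the scatter) in this assay, toward a somewhat lower number but with wide uncertainty. The estimate for compound 3 is 1200 nM, within a range from 250 nM to 5000 nM.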

Compound 3, half-maximal inhibitory concentration: 420 nM
Compound 3: the middle estimate sits 2.9-fold (0.46 log units) above what was measured; measured number inside the range.
By their numbers in this assay, from the lowest: compound 1; then compound 3; then compound 2.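

In this assay, the two groups on the carbonyl carbon are not interchangeable even though each has 10 heavy atoms, all carbon: naphthalen-2-yl in place of 1,2,3,4-tetrahydronaphthalen-5-yl gives a 10-fold lower number from compound 2 to compound 3 (1.00 log units; beyond the scatter). A second ring as such therefore does not carry the whole of the large loss seen earlier at this position. It is not free of cost either, as going from 4-fluorophenyl to naphthalen-2-yl still gives a 3.0-fold higher number from compound 1 to compound 3 (0.48 log units; beyond the scatter), and no measurement on hand accounts for these differences.

The change from compound 2 to compound 3 alters both ring saturation and the point of attachment, and the compounds shown cannot separate the two, which naphthalen-1-yl or 1,2,3,4-tetrahydronaphthalen-6-yl could help to do. Also open, on these data alone, is how unsubstituted phenyl or 4-aminophenyl on this carbonyl carbon would compare with 4-fluorophenyl.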